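Selenium substitution on a quinazoline series: pentyl to hydrogen

The source may hold more compounds than are shown below. What is called first, only, known or untested is meant among the compounds shown, and "the series" means these compounds.

Working notes on two measured compounds and one awaiting data. In a functional assay on HT-29 cells (Homo sapiens) for cytotoxicity, read by MTT assay, with a stated time of 72 h (a lower number here means a stronger inhibitor of growth, a higher number a weaker inhibitor of growth), compound 1 `CSc1ccc(CNc2nc([SeH])nc3ccccc23)cc1` gives 42900 nM, and compound 2 `CCCCC[Se]c1nc(NCc2ccccc2)c2ccccc2n1` gives 72700 nM; the two numbers lie within the usual scatter of one another, so compound 2 stands level with compound 1 in this assay. Compound 3 `[SeH]c1nc(NCc2ccccc2)c2ccccc2n1` differs from compound 2 by hydrogen in place of pentyl on a selenium. Within the data shown here, no measured pair shows this change, so the step is expected to stay within the scatter, with no direction assigned; compound 3 is therefore estimated at 55000 nM, range 20000 nM to 130000 nM, the expected step being a 1.3-fold lower number from compound 2 to compound 3 (0.12 log units; within the scatter).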

Compound 3, concentration for 50% growth inhibition: 62200 nM
Compound 3: middle estimate off by 1.1-fold (0.05 log units), on the low side, within the range that was stated.
By their numbers in this assay, from the lowest: compounds 1, 3 and 2 (each within the scatter of the next).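

In this assay, among these compounds, hydrogen in place of pentyl on a selenium gives a 1.2-fold lower number from compound 2 to compound 3 (0.07 log units; within the scatter) and so supplies the first measured pair at this position, with no separation between the two compounds. Hydrogen in place of methylsulfanyl on an aromatic carbon gives a 1.4-fold higher number from compound 1 to compound 3 (0.16 log units; within the scatter) and likewise shows no separation. No available evidence bears on these results.

From the compounds shown here alone, whether any group on the selenium can move the number beyond the scatter remains open. An amine or a carboxylic acid at the end of a pentyl chain would test this.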